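Extending the amine chain in a receptor-binding series

A few compounds are considered here, and "the series" means these few. Any claim that something is new, unique, unknown or untested is made for them only; others in the source may bear on it.

Three compounds sharing one core, differing only in the amine on an aromatic carbon, have been measured in an in vitro assay on 293-EBNA cells for binding affinity to corticotropin-releasing factor receptor 1 (Homo sapiens); on this read-out lower numbers stand for stronger inhibition and higher numbers for weaker inhibition. Compound 1 `Cc1nc(N2CCCCC2)c2nnn(-c3ccc(C(C)C)cc3Br)c2n1` carries a piperidin-1-yl group and gives 46 nM. Compound 2 `Cc1nc(N2CCCC2)c2nnn(-c3ccc(C(C)C)cc3Br)c2n1` carries a pyrrolidin-1-yl group and gives 194 nM. Compound 3 `CCN(CC)c1nc(C)nc2c1nnn2-c1ccc(C(C)C)cc1Br` carries a diethylamino group and gives 25.3 nM, the lowest of the three numbers, though its gap to compound 1 is within the scatter and only its gap to compound 2 is beyond it.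

Compound 4 `CCCCN(CC)c1nc(C)nc2c1nnn2-c1ccc(C(C)C)cc1Br` differs from compound 3 by ethyl in place of hydrogen on a saturated chain carbon, two bonds along the chain from a nitrogen on an aromatic ring. Of the measured steps, a 4.2-fold higher number from compound 1 to compound 2 (0.63 log units; beyond the scatter) and a 7.7-fold lower number from compound 2 to compound 3 (0.88 log units; beyond the scatter) show that reshaping this amine can shift the number modestly, while a 1.8-fold lower number from compound 1 to compound 3 (0.26 log units; within the scatter) shows that opening the ring changes little. Within the data shown here, none of these steps lengthens an open chain, so there is no direct precedent for the present change.

Given that, compound 4 is expected to sit close to compound 3, with a step of a 1.2-fold lower number from compound 3 to compound 4 (0.06 log units; within the scatter) in this assay, not clearly beyond the scatter in either direction. The estimate for compound 4 is 22 nM, expected to fall between 7 nM and 70 nM.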

Compound 4, inhibition constant: 7.5 nM
Compound 4: the middle estimate sits 2.9-fold (0.47 log units) above what was measured, and the stated range covers the measured number.
By their numbers in this assay, from the lowest: compound 4; then compounds 3 and 1 (each within the scatter of the next); then compound 2.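

In this assay, ethyl in place of hydrogen on a saturated chain carbon, two bonds along the chain from a nitrogen on an aromatic ring, turns diethylamino into butyl(ethyl)amino and gives a 3.4-fold lower number from compound 3 to compound 4 (0.53 log units; beyond the scatter), so lengthening this open chain lowers the number by more than the scatter, something the earlier changes between rings and the open chain could not show. The longer chain also separates compound 4 from both ring amines, with a 6.1-fold lower number from compound 1 to compound 4 (0.79 log units; beyond the scatter) and a 26-fold lower number from compound 2 to compound 4 (1.41 log units; beyond the scatter), the second of these large, which leaves compound 4 the most potent of the four in this series. Nothing available here bears on why the longer chain lowers the number.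

Going by these compounds, whether the number keeps falling with a longer chain such as hexyl, or with a second butyl in place of the remaining ethyl, stays open. The compounds shown also leave open whether only the length of the chain counts or whether its atoms matter too, a question that a methoxyethyl group in place of the butyl could help to answer.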